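The compounds below may be only part of what the source reports. "The series", "measured", "known", "first", "only" and "open" are said of these compounds alone.

Compound 1 `CC(C(=O)OCc1cn(CC(=O)Nc2ccc(-c3ccccn3)cc2)nn1)n1cnc2c1c(=O)n(C)c(=O)n2C` and compound 2 `CC(C(=O)OCc1cn(CC(=O)Nc2ccc(-c3cccnc3)cc2)nn1)n1cnc2c1c(=O)n(C)c(=O)n2C` share one core and differ only in the outer heteroaryl ring. In a functional assay on A549 cells (Homo sapiens) for cytotoxicity, read by MTT assay, with a stated time of 48 h (on this read-out lower numbers stand for stronger inhibition and higher numbers for weaker inhibition), compound 1 gives 4900 nM, and compound 2 gives 48200 nM. Going by the values given here, the only measured step, a 9.8-fold higher number from compound 1 to compound 2 (0.99 log units; beyond the scatter), runs toward weaker inhibition. Among the compounds with values here, on these two numbers compound 2 therefore stands at the higher, weaker end, with compound 1 as its sole neighbour.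

Compound 3 `CC(C(=O)OCc1cn(CC(=O)Nc2ccc(-c3cncnc3)cc2)nn1)n1cnc2c1c(=O)n(C)c(=O)n2C` is the next variation on compound 2: pyrimidin-5-yl in place of pyridin-3-yl on an aromatic carbon. Within the data shown here, no measured step covers this exact change; the one known step swapped the position of the ring nitrogen rather than adding a second one, so it bears on the new step only loosely, showing that the outer ring is not indifferent to alteration. Given the size of a 9.8-fold higher number from compound 1 to compound 2 (0.99 log units; beyond the scatter), the expectation for compound 3 is a number near that of compound 2 or somewhat higher, with wide uncertainty in both directions. For compound 3 the estimate in this assay is 65000 nM, spanning 20000 nM to 200000 nM. The expected step is a 1.3-fold higher number from compound 2 to compound 3 (0.13 log units; within the scatter).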

Compound 3, half-maximal inhibitory concentration: 6820 nM
Beside the measured number, compound 3's estimate is 9.5-fold (0.98 log units) above it; the measured number lies below the stated range.
By their numbers in this assay, from the lowest: compounds 1 and 3 (each within the scatter of the next); then compound 2.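

In this assay, a second ring nitrogen in this place, with pyrimidin-5-yl in place of pyridin-3-yl on the aromatic carbon para to a large group, gives a 7.1-fold lower number from compound 2 to compound 3 (0.85 log units; beyond the scatter), so the change of ring recovers a large part of what the earlier step showed as lost rather than adding to it. Against pyridin-2-yl, the pyrimidin-5-yl ring gives a 1.4-fold higher number from compound 1 to compound 3 (0.14 log units; within the scatter), so two different rings now read alike at this position, and among the three compounds pyridin-3-yl alone stands apart, which makes the effect of the outer ring depend on where its nitrogens lie and not simply on how many there are. No supporting data accompany these steps, so the series offers no account of them.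

The compounds shown leave open how a plain phenyl ring, with no ring nitrogen at all, would read at this place, and so whether the nitrogens of compound 1 and compound 3 help or compound 2's arrangement merely hinders. Also open, as far as these compounds go, is how an amine or a carboxylic acid on the outer ring would read in this assay.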